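The source may hold more compounds than are shown below. What is called first, only, known or untested is meant among the compounds shown, and "the series" means these compounds.

Compound 1 `O=c1cc(/C=C/c2ccc(O)cc2)oc2cc(O)ccc12` is, in a functional assay (on this read-out higher numbers stand for weaker inhibition and lower numbers for stronger inhibition), the weakest of the three measured compounds, giving 92000 nM. Compound 2 `O=c1cc(/C=C/c2ccc(O)c(O)c2)oc2ccccc12` gives 31200 nM in this assay, and compound 3 `O=c1cc(/C=C/c2ccc(O)c(O)c2)oc2cccc(O)c12` gives 16900 nM. Compound 4 `O=c1cc(/C=C/c2ccc(O)cc2)oc2cc(O)cc(O)c12` differs from compound 1 by hydroxy in place of hydrogen on an aromatic carbon. For the measured compounds named here, the only measured step of the same kind is a 1.8-fold lower number from compound 2 to compound 3 (0.27 log units; within the scatter), so the data point to little or no movement from such an addition. An added hydroxy on the shared core is therefore expected to lower the number only slightly, if at all, in this assay. Compound 4 is estimated at 55000 nM, with a likely range from 20000 nM to 150000 nM, which means an expected step of a 1.7-fold lower number from compound 1 to compound 4 (0.22 log units; within the scatter).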

Compound 4, half-maximal inhibitory concentration: 8500 nM
Compound 4: middle estimate off by 6.5-fold (0.81 log units), on the high side; the measured number lies below the stated range.
By their numbers in this assay, from the lowest: compounds 4, 3 and 2 (each within the scatter of the next, the first and the last beyond it); then compound 1.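

On the core of compound 1, a hydroxy on this aromatic carbon, meta to a hydroxy group, is a large change and not a marginal one: in this assay it gives an 11-fold lower number from compound 1 to compound 4 (1.03 log units; beyond the scatter). The same replacement therefore does not carry a fixed size from one core to another, as the two available steps show: the same change on two cores in this assay, a 1.8-fold lower number (0.27 log units; within the scatter) from compound 2 to compound 3 and an 11-fold lower number (1.03 log units; beyond the scatter) from compound 1 to compound 4, 5.9-fold (0.77 log units) apart, beyond the scatter of two such steps

Going by these compounds, with only these two pairs, it remains open which difference between the two cores sets the size of the step. On these data alone, it is also open how a methoxy or an amine would compare with hydroxy at this position.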